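Adding a Third Methoxy Group to a Styryl Lactone

The source may hold more compounds than are shown below. What is called first, only, known or untested is meant among the compounds shown, and "the series" means these compounds.

Measured compounds:
- Compound 1, `COc1ccc(/C=C/C2CC=CC(=O)O2)cc1OC`: 23.9 uM
- Compound 2, `COc1cc(/C=C/C2CC=CC(=O)O2)cc(OC)c1`: 8.1 uM

Both compounds share one core, a six-membered unsaturated lactone joined through a double bond to a methoxy-bearing benzene ring, and both were tested in a functional assay on U-251 cells (Homo sapiens) for inhibition, read by sulforhodamine B assay, with a stated time of 48 h; on this read-out lower numbers stand for stronger inhibition of growth and higher numbers for weaker inhibition of growth. Compound 1 gives 23.9 uM, while compound 2 gives 8.1 uM, the lower of the two numbers; the gap between them lies beyond the usual scatter, so compound 2 inhibits growth more strongly in this assay than compound 1.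

The next compound, compound 3, `COc1cc(/C=C/C2CC=CC(=O)O2)cc(OC)c1OC`, differs from compound 2 by one change: methoxy in place of hydrogen on an aromatic carbon. For the measured compounds named here, only two values are known, neither of which tests this exact change, so no measured step can guide the prediction. A small step is expected, with the number staying close to that of compound 2 or falling slightly, as a 1.4-fold lower number from compound 2 to compound 3 (0.13 log units; within the scatter). Compound 3 is therefore estimated at 6 uM, within a range from 2 uM to 20 uM.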

Compound 3, concentration for growth inhibition (reported as GI): 25.1 uM
Compound 3: middle estimate off by 4.2-fold (0.62 log units), on the low side; the measured number lies above the stated range.
By their numbers in this assay, from the lowest: compound 2; then compounds 1 and 3 (each within the scatter of the next).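

In this assay, a methoxy group on the ring carbon ortho to two methoxy groups and para to a group of 9 heavy atoms costs growth inhibition, with a 3.1-fold higher number from compound 2 to compound 3 (0.49 log units; beyond the scatter). The same added methoxy, read against the other dimethoxy compound, gives a 1.1-fold higher number from compound 1 to compound 3 (0.02 log units; within the scatter), so those two numbers sit within the scatter of each other, and more methoxy groups on the ring do not by themselves mean stronger inhibition of growth. Nothing available explains why this substitution raises the number from compound 2.

From the compounds shown here alone, whether a smaller group such as fluorine or a hydroxyl would be tolerated at this carbon remains open. So does the effect of a longer chain such as ethoxy or of a charged group such as an amine.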